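The source may hold more compounds than are shown below. What is called first, only, known or untested is meant among the compounds shown, and "the series" means these compounds.

In a functional assay on HCT-116 cells (Homo sapiens) for antiproliferative activity, read by MTT assay, with a stated time of 72 h (a lower number here means a stronger inhibitor, a higher number a weaker inhibitor), compound 1 `CC(C)(C)c1ccc(OCCCON2C(N)=NC(N)=NC23CCSCC3)cc1` gives 1 nM, and compound 2 `NC1=NC2(CCSCC2)N(OCCCOc2cccc(Cl)c2Cl)C(N)=N1` gives 1 nM. Compound 3 `NC1=NC2(CCOCC2)N(OCCCOc2ccc(Cl)cc2Cl)C(N)=N1` gives 880 nM, the highest of the three numbers and beyond the scatter of both others, which makes it the weakest inhibitor of the set. Compound 4 `NC1=NC2(CCOCC2)N(OCCCOc2ccc(Br)cc2)C(N)=N1` differs from compound 3 in one place: it carries 4-bromophenyl in place of 2,4-dichlorophenyl on an oxygen on a saturated carbon. Among the compounds with values here, no measured pair here shows this change on its own, so any forecast is rough, and its direction is uncertain. The expected step in this assay is small and not beyond the scatter, a 1.5-fold lower number from compound 3 to compound 4 (0.17 log units; within the scatter). For compound 4 the estimated value is 600 nM, with an expected range from 100 nM to 3000 nM.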

Compound 4, half-maximal inhibitory concentration: 320 nM
For compound 4 the middle estimate is 1.9-fold (0.27 log units) above the measured one, within the range that was stated.
By their numbers in this assay, from the lowest: compounds 1 and 2 (each within the scatter of the next); then compound 4; then compound 3.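

In this assay, the aromatic group on an oxygen on a saturated carbon can now be read on its own, with the rest of the molecule held constant: 4-bromophenyl in place of 2,4-dichlorophenyl gives a 2.8-fold lower number from compound 3 to compound 4 (0.44 log units; beyond the scatter). This single change therefore moves the number by a modest but real step, although it swaps two chlorines for one bromine in a single move. Nothing available explains the step.

The compounds shown do not separate the loss of chlorine from the gain of bromine. On these data alone, how a plain phenyl ring or an amine-bearing phenyl ring would read in this place also remains open.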